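A few compounds are considered here, and "the series" means these few. Any claim that something is new, unique, unknown or untested is made for them only; others in the source may bear on it.

Notes on the series. Within the data shown here, compound 2 `CCN(CC)CCCOc1cc2ncnc(Nc3nc4ccc(C(=O)Nc5c(C)cccc5Cl)cc4s3)c2cc1OC` stands as the only compound with a number in a functional assay on HCT-116 cells (Homo sapiens) for cytotoxicity, read by WST assay, with a stated time of 72 h (a higher number here means a weaker inhibitor, a lower number a stronger inhibitor), where compound 2 gives 13200 nM. Compound 1 `CCN(CC)CCCOc1cc2ncnc(Nc3nc4ccc(C(=O)Nc5c(C)cccc5C)cc4s3)c2cc1OC` in this assay gives > 100000 nM, which is a limit of the assay and not a number. Among the measured compounds shown here, the single measured step, an at least 7.5-fold lower number from compound 1 to compound 2 (0.87 log units; beyond the scatter), is a chloro in place of methyl on an aromatic carbon; its size rests on a limit, as the limit of > 100000 nM in this assay, at which 1 of the 2 values shown sits, shows. Compound 3 `COc1cc2c(Nc3nc4ccc(C(=O)Nc5c(C)cccc5Cl)cc4s3)ncnc2cc1OCCCN1CCCC1` differs from compound 2 by pyrrolidin-1-yl in place of diethylamino on a saturated chain carbon, three bonds along the chain from an oxygen on an aromatic ring. For the measured compounds named here, no measured step concerns this saturated chain position; the one measured step concerns a different place and gives no guide here, so no step beyond the scatter is expected. The expected step is a 1.0-fold lower number from compound 2 to compound 3 (0.01 log units; within the scatter). Compound 3 is therefore expected at 13000 nM in this assay, with a range from 5000 nM to 35000 nM.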

Compound 3, half-maximal inhibitory concentration: 63800 nM
The estimate for compound 3 lay 4.9-fold (0.69 log units) below the measured number; measured number outside the range, above it.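

In this assay this saturated chain position responds to the change, with a 4.8-fold higher number from compound 2 to compound 3 (0.68 log units; beyond the scatter), so the end of the 3-(diethylamino)propyl chain is not a neutral place in this pair. Diethylamino and pyrrolidin-1-yl match in their counts of heavy atoms, donors and acceptors, so the ring is the one counted difference between them, though this pair alone does not tell why the number moves. Unlike the earlier step, this one is read between two numbers rather than against a limit: the limit of > 100000 nM in this assay, at which 1 of the 3 values shown sits.

From the compounds shown here alone, whether piperidin-1-yl, morpholin-4-yl or dimethylamino at the end of the chain would sit nearer compound 2 or compound 3 stays open, as does the effect of a longer chain. Also open, going by these compounds, is whether the step from diethylamino to pyrrolidin-1-yl holds with methyl in place of chloro on the aromatic ring.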